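Shrinking the Amine Ring on a Cyanophenyl Core

The source may hold more compounds than are shown below. What is called first, only, known or untested is meant among the compounds shown, and "the series" means these compounds.

Compound 1 `Nc1nc(-c2cccs2)nc2sc(CN3CCCC3)cc12`: in an assay on CHO-K1 cells for antagonist activity at adenosine receptor A1 (Homo sapiens), read by a beta-galactosidase reporter, with stated times of 15 min and 6 h (a lower number here means a stronger inhibitor, a higher number a weaker inhibitor), compound 1 gives > 10000 nM, a limit of the assay rather than a number.
Compound 2 `C[C@@H]1CCC[C@H](C)N1Cc1cc2c(N)nc(-c3cccc(C#N)c3)nc2s1`: in this assay compound 2 gives 460 nM.

Compound 2 holds the only real number shown. The remaining value sits at the limit of > 10000 nM in this assay, at which 1 of the 2 values shown sits. Compound 3 `N#Cc1cccc(-c2nc(N)c3cc(CN4CCCC4)sc3n2)c1` differs from compound 2 by pyrrolidin-1-yl in place of 2,6-dimethylpiperidin-1-yl on a saturated chain carbon bound to an aromatic carbon. Compound 1 carries that same pyrrolidin-1-yl group and reaches only the limit. Replacing the 2,6-dimethylpiperidin-1-yl ring is expected to weaken binding in this assay beyond the scatter, with a 6.5-fold higher number from compound 2 to compound 3 (0.81 log units; beyond the scatter). Compound 3 is estimated at 3000 nM, within 800 nM to 12000 nM.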

Compound 3, inhibition constant: 130 nM
Beside the measured number, compound 3's estimate is 23-fold (1.36 log units) above it; the whole stated range lies above it.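

In this assay, on this saturated chain carbon bound to an aromatic carbon, the five-membered pyrrolidin-1-yl ring outperforms the 2,6-dimethylpiperidin-1-yl ring, with a 3.5-fold lower number from compound 2 to compound 3 (0.55 log units; beyond the scatter). Pyrrolidin-1-yl also does not by itself condemn a compound to weak binding: with 3-cyanophenyl in place of thiophen-2-yl on an aromatic carbon, there is an at least 76-fold lower number from compound 1 to compound 3 (1.88 log units; beyond the scatter). The value of compound 1 is a limit of the assay, not a number: the limit of > 10000 nM in this assay, at which 1 of the 3 values shown sits.

The compounds shown leave open how a plain piperidine ring, a four-membered azetidine ring or an open-chain dimethylamino group would fare at this place. Whether the two methyl groups or the ring size matters more also remains unresolved.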